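Series notes: amine substitution from compound 2 to compound 3

The compounds below may be only part of what the source reports. "The series", "measured", "known", "first", "only" and "open" are said of these compounds alone.

For the measured compounds named here, compound 2 `CN(C)CCn1c(=N)sc2cc(OC(F)(F)F)ccc21` gives in a functional assay on the whole organism with Rattus norvegicus as the target (on this read-out higher numbers stand for an effect only at larger amounts of compound and lower numbers for an effect already at smaller amounts), a value of 2.3 mg/kg, the only number so far. Compound 1 `CNCCn1c(=N)sc2cc(OC(F)(F)F)ccc21` gives in this assay only > 10 mg/kg, which is a limit of the assay rather than a number (the limit of > 10 mg/kg in this assay, at which 1 of the 2 values shown sits). Going by the values given here, the step of an at least 4.3-fold lower number from compound 1 to compound 2 (0.63 log units; beyond the scatter) is the single measured change. Compound 3 `CN(CCn1c(=N)sc2cc(OC(F)(F)F)ccc21)Cc1ccccc1` is not yet measured; it carries the change (phenyl in place of hydrogen on a saturated chain carbon bound to an amine nitrogen). The measured step also touches the amine nitrogen, but it sets methyl in place of hydrogen, whereas the change to compound 3 reads methyl to benzyl; the measured step therefore bears on it only loosely, and its size is no firm guide to the new step in this assay. Among the compounds with values here, no measured compound carries a benzyl on this amine. The expected step of a 1.3-fold higher number from compound 2 to compound 3 (0.12 log units; within the scatter) is accordingly small, with no settled direction. For compound 3 the estimate in this assay is 3 mg/kg, within 1 mg/kg to 10 mg/kg.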

Compound 3, dose for half-maximal effect: 7 mg/kg
Compound 3: middle estimate off by 2.3-fold (0.37 log units), on the low side, within the range that was stated.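

On the amine nitrogen, going from methyl to benzyl is not neutral in this assay: the step is a 3.0-fold higher number from compound 2 to compound 3 (0.48 log units; beyond the scatter), so compound 2 keeps the lower number of the two. Against hydrogen on that nitrogen, the benzyl step reads an at least 1.4-fold lower number from compound 1 to compound 3 (0.15 log units; that floor lies within the scatter), which does not set compound 3 firmly apart from compound 1. Compound 1 remains a limit of the assay rather than a number: the limit of > 10 mg/kg in this assay, at which 1 of the 3 values shown sits.

Going by these compounds, it stays open whether this rise in dose follows from the phenyl ring itself or from any group beyond methyl, and an ethyl or a phenethyl on this nitrogen would separate the two readings. Also open, on these data alone, is how a pyrrolidine in place of the open amine, or a longer chain between amine and core, would read on this series.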